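Dropping the isopentyl chain from compound 2

The compounds below may be only part of what the source reports. "The series", "measured", "known", "first", "only" and "open" are said of these compounds alone.

Values so far in a functional assay on MCF7 cells (Homo sapiens) for antiproliferative activity; a lower number here means a stronger inhibitor, a higher number a weaker inhibitor:
- compound 1 `CCCCOc1ccc(C(=O)Nc2cc3ccc(OC4CCN(C)CC4)c(C)c3oc2=O)cc1CC=C(C)C` gives 1440 nM
- compound 2 `Cc1c(OC2CCN(C)CC2)ccc2cc(NC(=O)c3ccc(O)c(CCC(C)C)c3)c(=O)oc12` gives 1250 nM

Compound 2 stands level with compound 1, the two numbers lying within the scatter of each other. Compound 3 `Cc1c(OC2CCN(C)CC2)ccc2cc(NC(=O)c3ccc(O)cc3)c(=O)oc12` differs from compound 2 by hydrogen in place of isopentyl on an aromatic carbon, ortho to a hydroxy group (hydrogen in place of isopentyl on an aromatic carbon). For the measured compounds named here, no measured pair isolates this change, so the direction is a judgement. Going by the values given here, compound 2 at 1250 nM and compound 1 at 1440 nM both keep a chain on that carbon, and no compound without one has a number yet. A moderate move to a higher number in this assay is expected, beyond the scatter. The expected change is a 4.0-fold higher number from compound 2 to compound 3 (0.60 log units; beyond the scatter) with wide uncertainty. For compound 3 the estimate is 5000 nM (expected range 1800 nM to 14000 nM).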

Compound 3, half-maximal inhibitory concentration: 1430 nM
Beside the measured number, compound 3's estimate is 3.5-fold (0.54 log units) above it; the whole stated range lies above it.
By their numbers in this assay, from the lowest: compounds 2, 3 and 1 (each within the scatter of the next).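

In this assay, for the compounds shown here, hydrogen in place of isopentyl on this aromatic carbon gives a 1.1-fold higher number from compound 2 to compound 3 (0.06 log units; within the scatter) and so provides the first direct reading of this change. With the hydroxy group and the rest of the structure held constant, removing all five carbons of the isopentyl chain produces no change beyond the scatter, so this antiproliferative read-out does not depend on that chain in this matched pair. No supporting data bear on why the chain can be removed without a measurable change.

The matched pair compares only isopentyl and hydrogen, so a longer chain, an amine or a carboxylic acid on this carbon remains untested within the compounds shown. It also leaves open whether this flat result would hold with a methoxy group in place of the hydroxy group.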